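The compounds below may be only part of what the source reports. "The series", "measured", "known", "first", "only" and "open" are said of these compounds alone.

Measured compounds:
- Compound 1, `CC1=CC[C@@H]([C@@](C)(O)CCCC(C)(C)NC(=S)N/N=C\c2ccc(C)cc2)CC1`: 6510 nM
- Compound 2, `COc1ccc(/C=N\NC(=S)NC(C)(C)CCC[C@](C)(O)[C@@H]2CC=C(C)CC2)cc1`: 6730 nM
- Compound 3, `CC1=CC[C@@H]([C@@](C)(O)CCCC(C)(C)NC(=S)N/N=C\c2ccccc2[N+](=O)[O-])CC1`: 20400 nM

In a functional assay on NCI/ADR cells (Homo sapiens) for cytotoxicity, read by sulforhodamine B assay (a lower number here means a stronger inhibitor of growth, a higher number a weaker inhibitor of growth), compound 3 gives the highest number of the three. Compound 1 and compound 2 sit close together, the change from one to the other being a 1.0-fold higher number from compound 1 to compound 2 (0.01 log units; within the scatter). Against both, compound 3 stands apart: the step was a 3.1-fold higher number from compound 1 to compound 3 (0.50 log units; beyond the scatter) and a 3.0-fold higher number from compound 2 to compound 3 (0.48 log units; beyond the scatter), so compound 3 is the weakest inhibitor of growth among the measured set.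

Compound 4, `CC1=CC[C@@H]([C@@](C)(O)CCCC(C)(C)NC(=S)N/N=C\c2ccccc2Cl)CC1`, differs from compound 3 in one place: chloro in place of nitro on an aromatic carbon. For the measured compounds named here, no measured step exchanges the nitro group for a chloro group, and no measured compound carries a chloro group anywhere, so none of the three steps bears directly on this change. The two steps that reached compound 3 both moved in the same direction and were modest in size. Going by the values given here, with no direct precedent, the step of a 1.7-fold lower number from compound 3 to compound 4 (0.23 log units; within the scatter) is expected to be small or within the scatter. Compound 4 is therefore estimated at 12000 nM, with a range from 4500 nM to 32000 nM.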

Compound 4, concentration for 50% growth inhibition: > 100000 nM
Compound 4 was reported as a limit; the forecaster's own chance of this, stated with the estimate: 5%; at least 8.3-fold (0.92 log units) between middle value and limit.
By their numbers in this assay, from the lowest: compounds 1 and 2 (each within the scatter of the next); then compound 3. At a limit, above all of these: compound 4.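

In this assay compound 4 is reported only as a limit: the limit of > 100000 nM in this assay, at which 1 of the 4 values shown sits. The earlier compounds shown here showed only a modest cost for 2-nitrophenyl, but they could not show how much depends on the group held on this aromatic carbon, ortho to a large group; exchanging nitro for chloro here weakens growth inhibition further, with an at least 4.9-fold higher number from compound 3 to compound 4 (0.69 log units; beyond the scatter). Against the two compounds carrying a 4-substituted phenyl, the 2-chlorophenyl change is large, with an at least 14-fold higher number from compound 2 to compound 4 (1.17 log units; beyond the scatter) and an at least 15-fold higher number from compound 1 to compound 4 (1.18 log units; beyond the scatter).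

Going by these compounds, the true size of each of these steps stays unknown, since all three end at a limit. The compounds shown also leave open whether chloro is poorly tolerated only at this place, as they include no 4-chlorophenyl compound, and whether an amine or a fluoro group on the same aromatic carbon would keep the growth inhibition of compound 3.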